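Working notes: replacing pyrrolidin-1-yl on a carbonyl carbon

This account rests on a few compounds, and the source may have more. Where it says the series, first, only, none or still open, it means among the compounds named here.

In an ADME assay on HeLa cells (Homo sapiens) for cytotoxicity, read by MTT assay (on this read-out higher numbers stand for weaker inhibition and lower numbers for stronger inhibition), compound 1 `COC(=O)[C@@H]1CCCN1C(=O)CCC(=O)Oc1ccc(C[C@H]2C(=O)OC[C@@H]2Cc2ccc(OC)c(OC)c2)cc1OC` gives 145000 nM and compound 2 `CCN(CC)C(=O)CCC(=O)Oc1ccc(C[C@H]2C(=O)OC[C@@H]2Cc2ccc(OC)c(OC)c2)cc1OC` gives 213000 nM while compound 3 `COc1ccc(C[C@H]2COC(=O)[C@@H]2Cc2ccc(OC(=O)CCC(=O)N3CCCC3)c(OC)c2)cc1OC` gives 201000 nM in the same range, all three within the scatter of one another. Compound 4 `COC(=O)[C@H](CC(C)C)NC(=O)CCC(=O)Oc1ccc(C[C@H]2C(=O)OC[C@@H]2Cc2ccc(OC)c(OC)c2)cc1OC` differs from compound 3 by (1-(methoxycarbonyl)-3-methylbutyl)amino in place of pyrrolidin-1-yl on a carbonyl carbon as (1-(methoxycarbonyl)-3-methylbutyl)amino in place of pyrrolidin-1-yl on a carbonyl carbon. Among the measured compounds shown here, two measured steps bear on this: the step of a 1.1-fold lower number from compound 2 to compound 3 (0.03 log units; within the scatter) at the same carbonyl carbon and the step of a 1.4-fold higher number from compound 1 to compound 3 (0.14 log units; within the scatter) involving methoxycarbonyl, which also stands in the entering group. For the measured compounds named here, no measured compound has the amide hydrogen that enters here. The expected step is a 1.2-fold lower number from compound 3 to compound 4 (0.07 log units; within the scatter) and no shift beyond the scatter is expected in this assay for now. For compound 4 the estimated value is 170000 nM with an expected range from 85000 nM to 320000 nM in this series.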

Compound 4, half-maximal inhibitory concentration: 53200 nM
For compound 4 the middle estimate is 3.2-fold (0.50 log units) above the measured one; measured number outside the range, below it.
By their numbers in this assay, from the lowest: compound 4; then compounds 1, 3 and 2 (each within the scatter of the next).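

In this assay this carbonyl carbon can move the number beyond the scatter, with a 3.8-fold lower number from compound 3 to compound 4 (0.58 log units; beyond the scatter) and a 4.0-fold lower number from compound 2 to compound 4 (0.60 log units; beyond the scatter) as well as a 2.7-fold lower number from compound 1 to compound 4 (0.44 log units; beyond the scatter) while compound 1, compound 2 and compound 3 stay within the scatter of one another. Methoxycarbonyl alone does not account for this, since compound 1 also carries it. No supporting data bear on the cause of this step.

Open, going by these compounds, is whether the amide hydrogen, the methoxycarbonyl or the 3-methylbutyl part carries the step. A plain ethylamino group or a carboxylic acid in place of the methoxycarbonyl would help separate these.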